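Alpha-methyl on the benzyl ether of the shared core

A few compounds are considered here, and "the series" means these few. Any claim that something is new, unique, unknown or untested is made for them only; others in the source may bear on it.

The series shares the core of compound 1 `COc1ccc(COCNc2n[n+]([O-])c3ccccc3[n+]2[O-])cc1` and varies the benzyl ether that sits on the amino linker. In a functional assay on PC-3 cells (Homo sapiens) for cytotoxicity, read by MTT assay, with a stated time of 72 h (a lower number here means a stronger inhibitor, a higher number a weaker inhibitor), compound 1 gives 14500 nM. Compound 2 `[O-][n+]1nc(NCOCc2ccccc2)[n+]([O-])c2ccccc21` carries the plain benzyl group, and in this assay compound 2 gives 13400 nM. The step of a 1.1-fold lower number from compound 1 to compound 2 (0.03 log units; within the scatter) is within the scatter, so compound 2 stands alongside compound 1 on the two numbers shown, with no separation between them that can be read as a change.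

Compound 3 `CC(OCNc1n[n+]([O-])c2ccccc2[n+]1[O-])c1ccccc1` is next. Relative to compound 2 it has methyl in place of hydrogen on a saturated chain carbon bound to an aromatic carbon and an oxygen on a saturated carbon. Going by the values given here, no measured step touches this saturated chain carbon; the only step in hand, from compound 1 to compound 2, concerns the aromatic ring and was within the scatter. There is therefore nothing in the data that points to a movement in this assay in either direction, and the expectation for the step is a 1.0-fold lower number from compound 2 to compound 3 (0.01 log units; within the scatter), a step not beyond the scatter. Compound 3 is accordingly expected to give about 13000 nM in this assay, with a plausible range from 5000 nM to 35000 nM.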

Compound 3, half-maximal inhibitory concentration: 6080 nM
Compound 3: middle estimate off by 2.1-fold (0.33 log units), on the high side, within the range that was stated.
By their numbers in this assay, from the lowest: compound 3; then compounds 2 and 1 (each within the scatter of the next).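

In this assay, going by these compounds alone, the saturated chain carbon bound to an aromatic carbon and an oxygen on a saturated carbon is the first place where a change separates two compounds: methyl in place of hydrogen gives a 2.2-fold lower number from compound 2 to compound 3 (0.34 log units; beyond the scatter) on the addition of a single carbon. The size of this step is modest, but the earlier step, a 1.1-fold lower number from compound 1 to compound 2 (0.03 log units; within the scatter), does not separate its two compounds, so on the three compounds shown this chain carbon responds where the methoxy on the aromatic carbon does not. No measurement on hand bears on why the added methyl goes with the lower number, so the finding rests on this one pair.

From the compounds shown here alone, whether a larger group on the same chain carbon, such as ethyl or a longer chain, or a group carrying oxygen or nitrogen, such as hydroxymethyl or an amine, would extend, hold or reverse the step remains open. Also open is whether the methyl keeps its step when methoxy sits on the aromatic ring, as the compounds shown carry these two groups only separately.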